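This account rests on a few compounds, and the source may have more. Where it says the series, first, only, none or still open, it means among the compounds named here.

Of the compounds shown here, three built on one shared core have been tested in an ADME assay on HEK293 cells (Homo sapiens) for cytotoxicity, read by MTT assay, with a stated time of 48 h; on this read-out lower numbers stand for stronger inhibition and higher numbers for weaker inhibition. Compound 1 `CCS(=O)(=O)Nc1ccc(NC(=O)c2cccc(C(F)(F)F)c2)cc1C` gives 210000 nM. Compound 2 `CCS(=O)(=O)Nc1ccc(NC(=O)c2cc(C(F)(F)F)cc(C(F)(F)F)c2)cc1C`, which carries a second trifluoromethyl group, gives 126000 nM. Compound 3 `Cc1cc(NC(=O)c2cc(C(F)(F)F)cc(C(F)(F)F)c2)ccc1NS(=O)(=O)C(F)(F)F` gives 182000 nM. The step of a 1.7-fold lower number from compound 1 to compound 2 (0.22 log units; within the scatter) and the step of a 1.4-fold higher number from compound 2 to compound 3 (0.16 log units; within the scatter) both stay within the scatter, so on the numbers shown compound 2 sits with the lowest value among three compounds that cannot be told apart.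

Compound 4 `CCS(=O)(=O)Nc1ccc(NC(=O)c2cc(C(F)(F)F)cc(C(F)(F)F)c2)cc1F` differs from compound 2 in one place: fluoro in place of methyl on an aromatic carbon. Neither measured step touches this position, so the two steps already seen give only a general sense that single small changes on this core have left this assay unmoved. The expectation for compound 4 is therefore a step of a 1.2-fold higher number from compound 2 to compound 4 (0.08 log units; within the scatter), which means no change beyond the scatter. Compound 4 is estimated at 150000 nM, with a likely range from 60000 nM to 350000 nM.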

Compound 4, half-maximal inhibitory concentration: > 250000 nM
Compound 4: a limit, no number; the forecaster's own chance of this, stated with the estimate: 20%; at least 1.6-fold (0.22 log units) between middle value and limit.
By their numbers in this assay, from the lowest: compounds 2, 3 and 1 (each within the scatter of the next). At a limit, above all of these: compound 4.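

Among these compounds, compound 4 gives the first reading for a change at the aromatic carbon ortho to the (ethylsulfonyl)amino group: in this assay compound 4 reads > 250000 nM, which is a limit of the assay and not a number. As far as these compounds go, the step is an at least 1.9-fold higher number from compound 2 to compound 4 (0.29 log units; that floor lies within the scatter), so fluoro in place of methyl at this position gave no sign of a lower number, while the true size of any rise stays unknown. Compound 4 is alone at this limit among the compounds shown: the limit of > 250000 nM in this assay, at which 1 of the 4 values shown sits.

From the compounds shown here alone, whether a chloro group, a methoxy group or an amine at this position would give a real number in this assay stays open. Also open, going by these compounds, is whether fluoro in place of methyl would read the same with trifluoromethyl on the sulfonyl sulfur, as in compound 3.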